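Amide nitrogen substituent variation on a shared core

The source may hold more compounds than are shown below. What is called first, only, known or untested is meant among the compounds shown, and "the series" means these compounds.

Compound 1, `CCCSc1nc(Cl)c2c(n1)N(Cc1ccccc1)C(C(=O)Nc1ccccc1)N2`: 50300 nM
Compound 2, `CCCSc1nc(Cl)c2c(n1)N(Cc1ccco1)C(C(=O)N1CCN(C)CC1)N2`: 13600 nM

In a functional assay on A549 cells (Homo sapiens) for antiproliferative activity, read by MTT assay, with a stated time of 72 h (a higher number here means a weaker inhibitor, a lower number a stronger inhibitor), compound 1 gives 50300 nM, the higher of the two numbers shown, while compound 2 gives 13600 nM. Compound 3, `CCCSc1nc(Cl)c2c(n1)N(Cc1ccccc1)C(C(=O)NCCCc1ccccc1)N2`, has not been measured. It differs from compound 1 in one place: 3-phenylpropyl in place of phenyl on an amide-type nitrogen. For the measured compounds named here, no step between measured compounds tests this change, so its size is uncertain. Compound 3 is expected to give a somewhat lower number than compound 1, a step of about a 1.7-fold lower number from compound 1 to compound 3 (0.22 log units; within the scatter), though this may fall within the scatter. The estimate for compound 3 is 30000 nM, with a range from 8000 nM to 100000 nM.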

Compound 3, half-maximal inhibitory concentration: 9430 nM
Compound 3: the middle estimate sits 3.2-fold (0.50 log units) above what was measured; low and high end bracket the measured number.
By their numbers in this assay, from the lowest: compounds 3 and 2 (each within the scatter of the next); then compound 1.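

Replacing phenyl with 3-phenylpropyl on the amide-type nitrogen gives a 5.3-fold lower number from compound 1 to compound 3 (0.73 log units; beyond the scatter) in this assay and shows that this position responds to the group it carries, even when both groups contain the same aromatic ring. For the compounds shown here, the step is modest but beyond the scatter, and it is the first single-place change read at this position. Nothing at hand accounts for it.

The compounds shown leave open whether the lower number depends on chain length, which benzyl, 2-phenylethyl or a longer chain on this nitrogen would test. They also leave open whether the terminal phenyl is needed, which a plain propyl group would test.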